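Replacing 3-methoxyphenyl with 4-methoxyphenyl on compound 2

The source may report more compounds than this note shows. Statements on the series, on what has been measured and on what is new or still open speak of the compounds shown alone.

Of the compounds shown here, three have been measured in a functional assay on HCT-116 cells (Homo sapiens) for inhibition, read by sulforhodamine B assay, with a stated time of 48 h, tested at 50 uM; a lower number here means less inhibition of growth, a higher number more inhibition of growth at the concentration tested. Compound 1 `COc1cccc(/C=C/C(=O)/C=C/c2ccc(OCc3cn(CCCCCOc4cc(=O)oc5ccccc45)nn3)c(OC)c2)c1` gives 36% and compound 2 `COc1cccc(/C=C/C(=O)/C=C/c2ccc(OCc3cn(CCCCOc4cc(=O)oc5ccccc45)nn3)c(OC)c2)c1` gives 44%, which places these two within the scatter of each other. Compound 3 `COc1cc(/C=C/C(=O)/C=C/c2cc(OC)c(OC)c(OC)c2)ccc1OCc1cn(CCCOc2cc(=O)oc3ccccc23)nn1` gives 76%, a number beyond the scatter above compound 2. Compound 2 therefore sits level with compound 1 and clearly short of compound 3.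

The next compound, compound 4 `COc1ccc(/C=C/C(=O)/C=C/c2ccc(OCc3cn(CCCCOc4cc(=O)oc5ccccc45)nn3)c(OC)c2)cc1`, starts from compound 2. The change is 4-methoxyphenyl in place of 3-methoxyphenyl on a double-bonded chain carbon bound to a double-bonded chain carbon. The two compounds have the same atoms, joined differently. For the measured compounds named here, no two measured compounds differ in one place alone, so the data offer no direct precedent for this change. Compound 3 differs from compound 2 in more than one place, and its higher number cannot be assigned to any single feature. With only compound 2 at 44% to go on, neither direction is favoured. The expected step is a number 2 percentage points higher from compound 2 to compound 4 (within the scatter), an estimate that stays within the scatter. For compound 4 the estimated value is 46%, with an expected range from 30% to 62%.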

Compound 4, percent growth inhibition at one concentration: 40%
Estimate against measurement, compound 4: 6 percentage points above; the range from low to high includes it.
By their numbers in this assay, from the lowest: compounds 1, 4 and 2 (each within the scatter of the next); then compound 3.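

In this assay, 4-methoxyphenyl in place of 3-methoxyphenyl on a double-bonded chain carbon bound to a double-bonded chain carbon gives a number 4 percentage points lower from compound 2 to compound 4 (within the scatter). For the compounds shown here, this is the first pair in the set that differs in one place, and so the first direct reading at this position: with the same atoms joined differently, the two methoxyphenyl groups are not told apart by this read-out at the concentration tested. Nothing in the data bears on why the exchange leaves the two compounds level.

Going by these compounds alone, what a different kind of group would do at this place remains open, for instance a phenyl ring carrying an amine or a carboxylic acid instead of the methoxy group, since the pair covers only two methoxyphenyl groups on one chain length. The higher number of compound 3 also remains unassigned, as that compound differs from compound 2 in more than one place and no single change among those shown accounts for it.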